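The compounds below may be only part of what the source reports. "The series", "measured", "known", "first", "only" and "open" are said of these compounds alone.

Measured compounds:
compound 1, `CCCSc1nc(N[C@@H]2C[C@H]2c2ccc(F)c(F)c2)c2nnn([C@@H]3C[C@H](OC(=O)CCC)[C@@H](O)[C@H]3O)c2n1`: 28.5%
compound 2, `CCCSc1nc(N[C@@H]2C[C@H]2c2ccc(F)c(F)c2)c2nnn([C@@H]3C[C@H](OC(=O)C(C)(C)C)[C@@H](O)[C@H]3O)c2n1`: "not active" (no number reported)
compound 3, `CCCSc1nc(N[C@@H]2C[C@H]2c2ccc(F)c(F)c2)c2nnn([C@@H]3C[C@H](OCCOC(=O)CCC)[C@@H](O)[C@H]3O)c2n1`: "not active" (no number reported)

In a functional assay on the whole organism (strain Sprague-Dawley) for inhibition, with Rattus norvegicus as the target, with a stated time of 0.5 h, at a dose of 5 mg/kg by the oral route (on this read-out higher numbers stand for more inhibition at the one dose given (going by the name of the read-out) and lower numbers for less inhibition), compound 1 gives 28.5%. Compound 2 gives "not active" (no number reported) in this assay, and compound 3 gives "not active" (no number reported) in this assay, so for compound 3 no single number stands, and it shares that outcome with compound 2. Only compound 1 of the three has a reported figure.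

The next compound, compound 4, is `CCCSc1nc(N[C@@H]2C[C@H]2c2ccc(F)c(F)c2)c2nnn([C@@H]3C[C@H](OCCOC(=O)c4cccnc4)[C@@H](O)[C@H]3O)c2n1`. It differs from compound 3 in one place: pyridin-3-yl in place of propyl on a carbonyl carbon. For the measured compounds named here, no step between two measured compounds covers this change, so its size cannot be read from the data. Since compound 3 has no number in this assay, the starting point is itself uncertain, and the writer expects compound 4 to stay near the low end, with no shift beyond the scatter that the data could support. Compound 4 is expected to give 10% in this assay, in a range from 0% to 30%.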

Compound 4, a percentage reported as inhibition, in the whole organism at one dose (the size of the read-out at that dose, not a potency): "not active" (no number reported)
Compound 4: no number reported, so the estimate cannot be set against anything.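

In this assay compound 3 gives "not active" (no number reported) and compound 4 gives "not active" (no number reported) and so no step can be read between them. The compounds shown leave open whether pyridin-3-yl in place of propyl alters this read-out at all. No evidence here bears on these results.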